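Exchange of Methylsulfanyl for a Selenium Group in Cytotoxicity Tests

The source may hold more compounds than are shown below. What is called first, only, known or untested is meant among the compounds shown, and "the series" means these compounds.

Measured compounds in a functional assay on PC-3 cells (Homo sapiens) for cytotoxicity, read by MTT assay, with a stated time of 72 h; on this read-out higher numbers stand for lower toxicity in this test and lower numbers for higher toxicity in this test:
Compound 1 `CS/C(=N\C(=O)c1csc([N+](=O)[O-])c1)NC(=O)c1csc([N+](=O)[O-])c1` gives a limit of the assay, > 100000 nM.
Compound 2 `O=C(/N=C(/NC(=O)c1cc(-c2ccccc2)nc2ccccc12)[Se]Cc1ccccc1)c1cc(-c2ccccc2)nc2ccccc12` gives a limit of the assay, > 100000 nM.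
Compound 3 `CS/C(=N\C(=O)c1cc(-c2ccccc2)nc2ccccc12)NC(=O)c1cc(-c2ccccc2)nc2ccccc12` gives a limit of the assay, > 100000 nM.

All three values sit at a limit rather than a number, as the limit of > 100000 nM in this assay, at which 3 of the 3 values shown sit, states. Compound 3 and compound 2 differ by a group of 8 heavy atoms (7 carbon, 1 selenium; one six-membered aromatic ring of carbon only) in place of a group of 2 heavy atoms (1 carbon, 1 sulfur; no ring), on a carbon with a double bond to nitrogen, and the step that the two limits leave unreadable from compound 3 to compound 2 cannot be read from the two limits. The difference between the core of compound 1 and the core of compound 3 is not broken down here.

Compound 4 `O=C(/N=C(/NC(=O)c1csc([N+](=O)[O-])c1)[Se]Cc1ccccc1)c1csc([N+](=O)[O-])c1` is not yet measured; it differs from compound 1 by a group of 8 heavy atoms (7 carbon, 1 selenium; one six-membered aromatic ring of carbon only) in place of a group of 2 heavy atoms (1 carbon, 1 sulfur; no ring), on a carbon with a double bond to nitrogen, the same change made from compound 3 to compound 2. Because compound 1 gives only the limit > 100000 nM and the same change gave the unreadable step that the two limits leave unreadable from compound 3 to compound 2, the step that the limit leaves unreadable from compound 1 to compound 4 is expected to be slight and most likely to end again at the limit. Compound 4 is therefore estimated at 150000 nM in this assay, with a range from 60000 nM to 500000 nM.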

Compound 4, concentration lethal to 50% of the cells: > 100000 nM
Compound 4 ended at the assay's limit; the forecaster's own chance of this, stated with the estimate: 85%; the middle value is on the limit's open side.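

In this assay compound 4 gives > 100000 nM, a limit and not a number. For the compounds shown here, compound 1 gives the limit > 100000 nM, so no step from compound 1 to compound 4 can be read. The compounds shown leave open how the selenium group and methylsulfanyl compare in this test, with every value at the same limit: the limit of > 100000 nM in this assay, at which 4 of the 4 values shown sit.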